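The compounds below may be only part of what the source reports. "The series", "measured", "known", "first", "only" and "open" are said of these compounds alone.

In a functional assay on HepG2 cells (Homo sapiens) for inhibition, read by MTT assay (on this read-out higher numbers stand for weaker inhibition and lower numbers for stronger inhibition), three amides built on one shared core have been measured. Compound 1 `COc1cc2ncnc(Nc3ccc(NC(=O)c4ccccc4C)cc3)c2cc1OC` gives 15000 nM, compound 2 `COc1cc2ncnc(Nc3ccc(NC(=O)c4ccc(F)cc4)cc3)c2cc1OC` gives 15000 nM, and compound 3 `COc1cc2ncnc(Nc3ccc(NC(=O)c4cccc(I)c4)cc3)c2cc1OC` gives 28000 nM, so compound 3 stands within the usual scatter of the other two. Compound 4 `COc1cc2ncnc(Nc3ccc(NC(=O)c4ccc(I)cc4)cc3)c2cc1OC` differs from compound 3 in one group: 4-iodophenyl in place of 3-iodophenyl on a carbonyl carbon. Three measured steps exchange the group at that same place: no change at the digits printed from compound 1 to compound 2 (within the scatter), a 1.9-fold higher number from compound 1 to compound 3 (0.27 log units; within the scatter) and a 1.9-fold higher number from compound 2 to compound 3 (0.27 log units; within the scatter). All lie within the scatter, so no step beyond it is expected in this assay. The expected change is a 1.4-fold lower number from compound 3 to compound 4 (0.15 log units; within the scatter). Compound 4 is estimated at 20000 nM, with an expected range of 9000 nM to 45000 nM.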

Compound 4, half-maximal inhibitory concentration: 40000 nM
Compound 4: the middle estimate sits 2.0-fold (0.30 log units) below what was measured; low and high end bracket the measured number.
By their numbers in this assay, from the lowest: compounds 1, 2, 3 and 4 (each within the scatter of the next, the first and the last beyond it).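

In this assay moving the iodine gives a 1.4-fold higher number from compound 3 to compound 4 (0.15 log units; within the scatter) and so does not separate 3-iodophenyl from 4-iodophenyl on this carbonyl carbon. Among these compounds, the change to 4-iodophenyl also brings the first steps at this place that lie beyond the scatter, namely a 2.7-fold higher number from compound 2 to compound 4 (0.43 log units; beyond the scatter) and a 2.7-fold higher number from compound 1 to compound 4 (0.43 log units; beyond the scatter) and so the choice of group here can move the number, if only modestly. Nothing available explains these shifts. Still open, from the compounds shown here alone, is how far the number would move with a group carrying an amine or a carboxylic acid on this carbonyl carbon, or with a longer chain there.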